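Dichlorophenyl swap at the imidazole carbon between two nitrogens

A few compounds are considered here, and "the series" means these few. Any claim that something is new, unique, unknown or untested is made for them only; others in the source may bear on it.

Going by the values given here, compound 2 `O=C1COc2ccc(-c3[nH]c(-c4ccc(F)cc4)nc3-c3ccccc3)cc2N1` is one of two compounds measured in a functional assay on DLD-1 cells (Homo sapiens) for cytotoxicity, read by colorimetric assay and MTT assay, with a stated time of 3 days, tested at 1 uM; a lower number here means a stronger effect, a higher number a weaker effect of the compound at the concentration tested. In this assay compound 2 gives 94.8%, and compound 1 `O=C1COc2ccc(-c3[nH]c(-c4ccc(C(F)(F)F)cc4)nc3-c3ccccc3)cc2N1` gives 95%; the step of a number 0.2 percentage points lower from compound 1 to compound 2 (within the scatter) is within the scatter, so the two numbers cannot be told apart. Compound 3 `O=C1COc2ccc(-c3[nH]c(-c4ccc(Cl)cc4Cl)nc3-c3ccccc3)cc2N1` has not been measured yet. It differs from compound 2 by one change: 2,4-dichlorophenyl in place of 4-fluorophenyl on an aromatic carbon. Among the compounds with values here, no measured step touches this change; the only known step is the move from trifluoromethyl to fluoro on the same aromatic carbon, which left the read-out unchanged. On that basis a step of no more than the scatter is expected, as a number 1.8 percentage points lower from compound 2 to compound 3 (within the scatter). Compound 3 is therefore expected to give 93% in this assay, within a range from 80% to 101%.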

Compound 3, a percentage reported as activity, at one concentration (the size of the read-out at that concentration, not a potency): 97.8%
The estimate for compound 3 lay 4.8 percentage points below the measured number; the measured number falls inside the stated range.
By their numbers in this assay, from the lowest: compounds 2, 1 and 3 (each within the scatter of the next).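

At this position, on the aromatic carbon between two ring nitrogen atoms, the earlier pair had only compared single para-type substituents in the sense of one group on the phenyl ring; compound 3 now tests 2,4-dichlorophenyl, which carries two chlorine atoms. In this assay this change gives a number 3 percentage points higher from compound 2 to compound 3 (within the scatter) and, against the trifluoromethyl compound, a number 2.8 percentage points higher from compound 1 to compound 3 (within the scatter). All three aryl groups tried here therefore give read-outs that cannot be told apart at this single concentration, and no separate measurement bears on why.

On these data alone, whether a phenyl ring carrying an amine or a carboxylic acid would behave the same remains open, as does a longer chain in place of the ring. A single concentration also gives no potency for any of these compounds.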